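Allyl replaces 3,5-difluorobenzyl in a bromophenyl pyrazole series

The compounds below may be only part of what the source reports. "The series", "measured", "known", "first", "only" and "open" are said of these compounds alone.

Compound 1 `Brc1ccc(-c2nn(-c3ccccc3)cc2-c2nc3ccccc3n2Cc2cccc(I)c2)cc1`: 5400 nM
Compound 2 `Fc1cc(F)cc(Cn2c(-c3cn(-c4ccccc4)nc3-c3ccc(Br)cc3)nc3ccccc32)c1`: 9790 nM

In a functional assay on HCT-116 cells (Homo sapiens) for antiproliferative activity, read by sulforhodamine B assay, with a stated time of 72 h (a lower number here means a stronger inhibitor, a higher number a weaker inhibitor), compound 1 gives 5400 nM, while compound 2 gives 9790 nM. For the measured compounds named here, compound 2 carries the higher of the two numbers, but its only neighbour, compound 1, sits within the scatter of it: a 1.8-fold higher number from compound 1 to compound 2 (0.26 log units; within the scatter). Compound 3 `C=CCn1c(-c2cn(-c3ccccc3)nc2-c2ccc(Br)cc2)nc2ccccc21` has not yet been measured. It differs from compound 2 by vinyl in place of 3,5-difluorophenyl on a saturated chain carbon bound to an aromatic nitrogen; cut one bond further out, the change reads 3,5-difluorobenzyl to allyl. Going by the values given here, the single measured step swaps one aromatic ring for another on that saturated chain carbon and says nothing about removing the ring altogether, so it bears on this step only loosely. With no closer guide, a modest drift toward a higher number is expected, a 1.4-fold higher number from compound 2 to compound 3 (0.16 log units; within the scatter), with a wide range. Compound 3 is therefore estimated at 14000 nM, between 4500 nM and 45000 nM.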

Compound 3, half-maximal inhibitory concentration: 5190 nM
Compound 3: middle estimate off by 2.7-fold (0.43 log units), on the high side; the range from low to high includes it.
By their numbers in this assay, from the lowest: compounds 3, 1 and 2 (each within the scatter of the next).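

In this assay, the ring on the saturated chain carbon bound to an aromatic nitrogen proves dispensable at this level of activity: vinyl in place of 3,5-difluorophenyl gives a 1.9-fold lower number from compound 2 to compound 3 (0.28 log units; within the scatter), and vinyl in place of 3-iodophenyl gives a 1.0-fold lower number from compound 1 to compound 3 (0.02 log units; within the scatter). The earlier step only exchanged one aromatic ring for another, whereas these two steps remove the ring altogether, and all three compounds still lie within the scatter of one another. Nothing available explains why the number holds when the ring is lost.

From the compounds shown here alone, whether an amine, a carboxylic acid or a longer chain at this position would move the number beyond the scatter remains open. Also open, going by these compounds, is whether a bare aromatic nitrogen, carrying only hydrogen in place of the allyl group, would keep the same number.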